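The source may report more compounds than this note shows. Statements on the series, on what has been measured and on what is new or still open speak of the compounds shown alone.

Measured so far in a functional assay on a cell-free system (plasma) with sterol O-acyltransferase, Soat (Rattus norvegicus) as the target; a lower number here means that less compound is needed, a higher number that more compound is needed for the effect:
compound 1 `Cc1cc(C)c(NC(=O)N(Cc2ccc(-c3n[nH]c(C)n3)cc2)C2CCCCCC2)c(C)c1`: > 1 mg/kg
compound 2 `COc1ccccc1CN(Cc1cccc(-c2cc[nH]n2)c1)C(=O)Nc1c(SC)cc(C)nc1SC`: > 0.1 mg/kg

Compound 1 gives > 1 mg/kg in this assay, which is a limit of the assay and not a number. Compound 2 likewise reaches only a limit, > 0.1 mg/kg, in this assay. Going by the values given here, compound 1 therefore stands on no number at all: one of the two values sits at the limit of > 1 mg/kg in this assay, at which 1 of the 2 values shown sits, the other at the limit of > 0.1 mg/kg in this assay, at which 1 of the 2 values shown sits, and no step between measured compounds can be drawn from them.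

Compound 3 `Cc1cc(C)c(NC(=O)N(Cc2ccc(-c3ccn(C)n3)cc2)C2CCCCCC2)c(C)c1` differs from compound 1 by 1-methyl-1H-pyrazol-3-yl in place of 5-methyl-1H-1,2,4-triazol-3-yl on an aromatic carbon. With compound 1 known only as a limit, > 1 mg/kg, there is no measured basis for a direction. The step that the limit leaves unreadable from compound 1 to compound 3 is expected to be none beyond the usual scatter, in no firm direction. Compound 3 is expected at 3 mg/kg in this assay, within 1 mg/kg to 10 mg/kg, and quite possibly again reported only as a limit.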

Compound 3, dose for half-maximal effect: < 1 mg/kg
Compound 3 was reported as a limit (the forecaster's own chance of this, stated with the estimate: 60%); middle value at least 3.0-fold (0.47 log units) away from the limit.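

Going by these compounds alone, on the aromatic carbon para to a large group, 1-methyl-1H-pyrazol-3-yl in place of 5-methyl-1H-1,2,4-triazol-3-yl gives a number no higher from compound 1 to compound 3 (the limit leaves the size open) in this assay, a direction that the earlier compounds could not give. Compound 3 gives < 1 mg/kg, which is a limit of the assay and not a number, so this position responds to the change but the size of the response cannot be read. The change alters the hydrogen-bond donor count and the ring hetero atoms together, and this single step cannot separate the two.

As far as these compounds go, the size of the step stays open until compound 1 and compound 3 have numbers rather than limits. Also open, from the compounds shown here alone, is how a carboxylic acid, an amine or a plain phenyl ring would behave at this place on the core of compound 3.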